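A few compounds are considered here, and "the series" means these few. Any claim that something is new, unique, unknown or untested is made for them only; others in the source may bear on it.

Working notes on the series. In a functional assay on MCF7 cells (Homo sapiens) for cytotoxicity, read by sulforhodamine B assay, with a stated time of 48 h (a lower number here means a stronger inhibitor, a higher number a weaker inhibitor), compound 1 (`COc1ccc(/C=C/C(=O)c2ccc(N)c(-c3ccc(F)cc3)c2)cc1O`) stands without a single number, its entry being "not determined" (no result reported) and so giving no starting point. Among the compounds with values here, the only numerical reading comes from compound 2 (`COc1ccc(/C=C/C(=O)c2ccc(NC(C)=O)c(-c3ccc(F)cc3)c2)cc1OC`), at 15000 nM in the same test. Compound 3 (`COc1cc(/C=C/C(=O)c2ccc(N)c(-c3ccc(F)cc3)c2)ccc1O`) carries 4-hydroxy-3-methoxyphenyl in place of 3-hydroxy-4-methoxyphenyl on a double-bonded chain carbon bound to a double-bonded chain carbon. Within the data shown here, no measured step sizes this exchange. The expectation in this assay is therefore no step beyond the scatter, with no direction assigned. The estimate leans on compound 2 at 15000 nM as the sole reference, and the range is kept wide. Compound 3 is expected at 10000 nM with an estimated range from 3000 nM to 35000 nM in this read-out.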

Compound 3, half-maximal inhibitory concentration: 10500 nM
Compound 3: middle estimate off by 1.1-fold (0.02 log units), on the low side, within the range that was stated.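

In this assay, within the data shown here, compound 1 has no single number, so compound 3 at 10500 nM gives no new step against it. The compounds shown leave open what the exchange of 3-hydroxy-4-methoxyphenyl for 4-hydroxy-3-methoxyphenyl does to potency. No evidence bears on this result.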